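Nitro in place of fluoro on the aryl ring of compound 1

This account rests on a few compounds, and the source may have more. Where it says the series, first, only, none or still open, it means among the compounds named here.

Measured compounds:
compound 1 `Fc1ccc(-c2nnc3nnc(N4CCCC4)n3n2)cc1`: 4560 nM
compound 2 `C1CCC(c2nnc3nnc(N4CCCC4)nn23)CC1`: 23800 nM
compound 3 `CCCCCc1nnc2nnc(N3CCCC3)nn12`: 42500 nM

In a functional assay on HL-60 cells (Homo sapiens) for cytotoxicity, read by MTT assay, with a stated time of 72 h (a higher number here means a weaker inhibitor, a lower number a stronger inhibitor), compound 1 gives the lowest number of the three, and compound 2, its nearest neighbour, gives a number beyond the scatter above it, while compound 3 stands furthest away. For the measured compounds named here, the only single-point step among the measured compounds is a 1.8-fold higher number from compound 2 to compound 3 (0.25 log units; within the scatter), an exchange of one saturated group for another on the shared core; it says nothing about substituents on an aryl ring.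

The next compound, compound 4 `O=[N+]([O-])c1ccc(-c2nnc3nnc(N4CCCC4)n3n2)cc1`, keeps the aryl ring of compound 1 and changes only its substituent: nitro in place of fluoro on an aromatic carbon. Going by the values given here, no measured step bears on this exchange. Compound 1 and compound 2 differ in having an aryl ring or a saturated ring on the core, and their values show that the aryl ring goes with the lower number, but nothing measured tells how a different group on that ring shifts the number. Among the compounds with values here, with no bearing step, the expectation for compound 4 is a step of a 1.1-fold lower number from compound 1 to compound 4 (0.06 log units; within the scatter), which is within the scatter, and the estimate for compound 4 in this assay is 4000 nM with a range from 1300 nM to 12000 nM.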

Compound 4, half-maximal inhibitory concentration: > 100000 nM
Compound 4: only a limit was reported; the forecaster's own chance of this, stated with the estimate: 3%; middle value at least 25-fold (1.39 log units) away from the limit.
By their numbers in this assay, from the lowest: compound 1; then compounds 2 and 3 (each within the scatter of the next). At a limit, above all of these: compound 4.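

In this assay compound 4 gives > 100000 nM, which is a limit of the assay and not a number. Nitro in place of fluoro on the aromatic carbon para to a large group gives an at least 21-fold higher number from compound 1 to compound 4 (1.34 log units; beyond the scatter), the first step in this series at this position, and it shows that the substituent there strongly affects the read-out and that an aryl ring on the shared core does not by itself keep the number of compound 1. The size of this step is known only from one side, and its reading rests on a single value at the limit: the limit of > 100000 nM in this assay, at which 1 of the 4 values shown sits.

From the compounds shown here alone, it remains open whether this large step belongs to nitro in particular or would follow any replacement of fluoro, a question that an amine, a methoxy group or plain hydrogen at the same position would help to settle. Going by these compounds, how far beyond the limit compound 4 really lies also remains open, as does whether a carboxylic acid or a longer chain at this position would stay close to compound 1.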